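Fluoro for Chloro on the Shared Core of Compound 2

This account rests on a few compounds, and the source may have more. Where it says the series, first, only, none or still open, it means among the compounds named here.

Of the compounds shown here, two have been measured so far. Compound 1 `COc1ccc(C(=O)/C=C/c2ccc(Br)cc2)cc1` in an ADME assay on cells (Mus musculus, strain Balb/c) for cytotoxicity, read by MTT assay, with a stated time of 48 h (a higher number here means that more compound is tolerated, a lower number that less compound is tolerated), gives 93700 nM. Compound 2 `COc1ccc(C(/C=C/c2ccc(Cl)cc2)=N/O)cc1` in this assay gives 291000 nM, the higher of the two numbers, and the gap from compound 1 lies beyond the usual scatter. For the measured compounds named here, compound 2 thus stands at the top of the numbers obtained to date, with compound 1 as its only neighbour.

Compound 3 `COc1ccc(C(/C=C/c2ccc(F)cc2)=N/O)cc1` is not yet measured. It differs from compound 2 at a single place: fluoro in place of chloro on an aromatic carbon. The halogen sits on the same aromatic carbon in both compounds, para to a large group.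

Going by the values given here, no pair of measured compounds differs in one place, so the size of this step cannot be read from the data. Because compound 2 gives 291000 nM and the change is a swap of one halogen for another, the step from compound 2 to compound 3 is expected to lie within the scatter, with no clear direction. Compound 3 is therefore estimated at 300000 nM in this assay, with a range of 120000 nM to 700000 nM. The step this estimate implies is expected to be a 1.0-fold higher number from compound 2 to compound 3 (0.01 log units; within the scatter).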

Compound 3, half-maximal cytotoxic concentration: 13500 nM
Compound 3: the middle estimate sits 22-fold (1.35 log units) above what was measured; the whole stated range lies above it.
By their numbers in this assay, from the lowest: compound 3; then compound 1; then compound 2.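

In this assay, for the compounds shown here, the exchange of chloro for fluoro on an aromatic carbon, para to a large group, gives the only one-place comparison available, and it amounts to a 22-fold lower number from compound 2 to compound 3 (1.33 log units; beyond the scatter). This shows that the position is far from indifferent to which halogen it carries: the swap replaces 1 heavy atom with 1 heavy atom, leaves the counts of hydrogen-bond donors and acceptors at 0 on both sides and adds no net charge, yet much less compound is tolerated with fluoro than with chloro. Nothing available accounts for a change of this size from so small an exchange.

As far as these compounds go, it remains open whether this large step is specific to fluoro or whether other groups at the same aromatic carbon, such as an amine, a methoxy group or a carboxylic acid, would also shift the number in this assay. From the compounds shown here alone, it is equally open whether the exchange of chloro for fluoro would produce a step of similar size on the core of compound 1, which carries a carbonyl and bromo.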